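The source may hold more compounds than are shown below. What is called first, only, known or untested is meant among the compounds shown, and "the series" means these compounds.

Compound 1, `O=C(Nc1ccccc1Br)N[C@@H]1CCN(c2ccccn2)C1`, gives in a functional assay for antagonist activity at transient receptor potential cation channel subfamily V member 1 (Rattus norvegicus), read by FLIPR (on this read-out higher numbers stand for higher potency (the scale is a negative logarithm) and lower numbers for lower potency), only a limit, < 6.6, not a number.
Compound 2, `Cc1cccc(N2CC[C@@H](NC(=O)Nc3ccccc3Br)C2)c1`, gives in this assay 7.7.

Within the data shown here, compound 2 thus holds the only actual number in this assay among the two measured compounds; the other value is a limit, as the limit of < 6.6 in this assay, at which 1 of the 2 values shown sits, records. Compound 3, `Cc1ccc(N2CC[C@@H](NC(=O)Nc3ccccc3Br)C2)nc1`, has not yet been measured. It differs from compound 2 in one place: 5-methylpyridin-2-yl in place of 3-methylphenyl on an amine nitrogen in a ring. Among the measured compounds shown here, one measured step bears on this change. Going from the pyridin-2-yl group to a methylphenyl group on the same ring nitrogen gave a number at least 1.10 log units higher from compound 1 to compound 2 (beyond the scatter). The new group in compound 3 carries the pyridine nitrogen of compound 1 together with a methyl group, so the change from compound 2 to compound 3 undoes part of that step while keeping a methyl on the ring. A drop beyond the scatter in this assay is therefore expected, though probably smaller than the full step seen from compound 1 to compound 2. For compound 3 the expected step is a number 0.70 log units lower from compound 2 to compound 3 (beyond the scatter). Compound 3 is estimated at 7, within a range from 6.4 to 7.6.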

Compound 3, negative logarithm of the antagonist equilibrium constant: < 6.7
Compound 3: no number, only a limit; the forecaster's own chance of this, stated with the estimate: 25%; middle value at least 0.30 log units away from the limit.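

Swapping 3-methylphenyl for 5-methylpyridin-2-yl on the amine nitrogen in the ring gives, in this assay, a number at least 1.00 log units lower from compound 2 to compound 3 (beyond the scatter). Compound 1 had already shown a low result with an unsubstituted pyridin-2-yl group, and this new pair adds that a methyl on the aromatic ring is not enough to keep the potency of compound 2 once that ring contains a nitrogen. Compound 1 and compound 3 both give only limits rather than numbers, so the step between them, the added methyl, cannot be read.

As far as these compounds go, the true potency of compound 3 therefore remains unknown, as does whether its methyl group makes any difference on the pyridine ring. Also open, from the compounds shown here alone, is how the result would change with an unsubstituted phenyl group on the ring nitrogen, or with a chlorine or methoxy group in place of the methyl on the 3-methylphenyl group of compound 2, which would show whether the methyl itself matters on the all-carbon ring.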